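The source may report more compounds than this note shows. Statements on the series, on what has been measured and on what is new or still open speak of the compounds shown alone.

Of the compounds shown here, two sharing a core have so far been tested in an ADME assay on Caco-2 cells (Homo sapiens) for permeability, in the apical to basolateral direction; a lower number here means that the compound crosses the layer more slowly, a higher number that the compound crosses the layer faster. Compound 1 `Cn1nc2c(=O)n(CC3(O)CCN(Cc4ccc(-c5ccco5)cc4Cl)CC3)cnc2c1-c1ccc(F)cc1` gives 6.84 10^-6 cm/s, and compound 2 `Cn1nc2c(=O)n(CC3(O)CCN(Cc4ccc(-c5cccs5)cc4Cl)CC3)cnc2c1-c1ccc(CN)cc1` gives 0.8 10^-6 cm/s. That makes compound 2 the lower of the two numbers, with a gap to compound 1 that lies beyond the usual scatter of repeated measurements. These two compounds differ in more than one place, so the gap cannot be tied to any single group.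

Compound 3 `Cn1nc2c(=O)n(CC3(O)CCN(Cc4ccc(-c5ccco5)cc4Cl)CC3)cnc2c1-c1ccc(CN)cc1` keeps everything in compound 2 except one group on an aromatic carbon, with furan-2-yl in place of thiophen-2-yl (furan-2-yl in place of thiophen-2-yl on an aromatic carbon). Going by the values given here, the swap trades one five-membered aromatic ring with 1 hetero atom for another, and no measured pair shows this swap on its own. With compound 2 at 0.8 10^-6 cm/s as the closest reference, no step beyond the scatter is expected in this assay. The expected step is no change at the digits printed from compound 2 to compound 3 (within the scatter). For compound 3 the estimated value is 0.8 10^-6 cm/s, with an expected range from 0.35 10^-6 cm/s to 1.8 10^-6 cm/s.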

Compound 3, apparent permeability: 0.92 10^-6 cm/s
Compound 3: the middle estimate sits 1.2-fold (0.06 log units) below what was measured, within the range that was stated.
By their numbers in this assay, from the lowest: compounds 2 and 3 (each within the scatter of the next); then compound 1.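

In this assay, furan-2-yl in place of thiophen-2-yl, on an aromatic carbon para to a large group, gives a 1.2-fold higher number from compound 2 to compound 3 (0.06 log units; within the scatter) in a background that carries aminomethyl, so this exchange of one five-membered aromatic ring for another cannot be told apart from repeat-measurement noise. Going by these compounds alone, the second single change, aminomethyl in place of fluoro on an aromatic carbon with the furan-2-yl group held constant, gives a 7.4-fold lower number from compound 1 to compound 3 (0.87 log units; beyond the scatter) and is the only one of the two steps that lies beyond the scatter. Nothing available here explains the size of either step.

The compounds shown leave open whether the near-equality of the two rings would also hold with fluoro in place of aminomethyl, and whether a different group at the same carbon, such as phenyl or thiazol-2-yl, would behave like furan-2-yl and thiophen-2-yl. They also leave open how a hydroxymethyl or a dimethylaminomethyl group would compare with aminomethyl and fluoro in this measurement.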